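This account rests on a few compounds, and the source may have more. Where it says the series, first, only, none or still open, it means among the compounds named here.

Measured compounds:
compound 1 `Nc1cc(N)c2nc(-c3ccccc3)c(NCc3ccc(Cl)c(Cl)c3)nc2c1` with 20000 nM
compound 2 `CCOC(=O)[C@H](CCC(=O)O)NC(=O)c1ccc(Sc2nc3cc(N)cc(N)c3nc2-c2ccccc2)cc1` with 16200 nM

Of the compounds shown here, two built on the same core have been measured in a functional assay on SF-268 cells (Homo sapiens) for inhibition, read by sulforhodamine B assay, with a stated time of 48 h; a lower number here means a stronger inhibitor of growth, a higher number a weaker inhibitor of growth. Compound 1 gives 20000 nM in this assay, and compound 2 gives 16200 nM in this assay. Both numbers are high, and the gap between them lies within the usual scatter of repeated measurements, so neither compound can be placed above the other; compound 1 simply stands alongside compound 2 at the weak end of what these two numbers show.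

Compound 3 `COc1ccc(CNc2nc3cc(N)cc(N)c3nc2-c2ccccc2)cc1OC` has not yet been measured. It departs from compound 1 in a single place: 3,4-dimethoxyphenyl in place of 3,4-dichlorophenyl on a saturated chain carbon bound to a nitrogen on an aromatic ring. Among the measured compounds shown here, no measured pair in this set shows how such a swap plays out on this core, and compound 2 differs from compound 1 in a different part of the molecule, so the expectation rests on compound 1 alone. With nothing to point the other way, the expected step is a 1.1-fold higher number from compound 1 to compound 3 (0.04 log units; within the scatter), a change not beyond the scatter. Compound 3 is therefore estimated at 22000 nM, with a range from 8000 nM to 60000 nM.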

Compound 3, concentration for 50% growth inhibition: 14800 nM
Compound 3: middle estimate off by 1.5-fold (0.17 log units), on the high side; the range from low to high includes it.
By their numbers in this assay, from the lowest: compounds 3, 2 and 1 (each within the scatter of the next).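

Placing 3,4-dimethoxyphenyl where compound 1 carries 3,4-dichlorophenyl, on a saturated chain carbon bound to a nitrogen on an aromatic ring, gives a 1.4-fold lower number from compound 1 to compound 3 (0.13 log units; within the scatter) in this assay and so leaves the two compounds indistinguishable in this read-out. Among the compounds shown here, this is the first direct look at this position: the entering group has more heavy atoms and carries hydrogen-bond acceptors that the leaving group lacks, yet neither difference comes with a step beyond the scatter, and the pair stays in the same high range as compound 2. Nothing available explains why this exchange leaves the number within the scatter.

From the compounds shown here alone, whether this position can ever shift growth inhibition remains open, since this single exchange of two substituted phenyl groups says nothing about an amine or a carboxylic acid on that ring, or about a longer chain between the ring and the nitrogen. Also unresolved is whether changes elsewhere on the shared core, such as replacing its phenyl group or its two amino groups, would move the number in this assay beyond the scatter.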